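A few compounds are considered here, and "the series" means these few. Any claim that something is new, unique, unknown or untested is made for them only; others in the source may bear on it.

Working notes on the series. In a functional assay on SEM cells (Homo sapiens) for cytotoxicity, read by MTT assay, with a stated time of 72 h (on this read-out higher numbers stand for weaker inhibition and lower numbers for stronger inhibition), compound 2 (`COC(=O)c1sc2ccccc2c1Nc1cc(OC)c(OC)c(OC)c1`) gives 179 nM and compound 1 (`CCOC(=O)c1sc2cccc(C)c2c1Nc1cc(OC)c(OC)c(OC)c1`) gives 1930 nM as its reading, so compound 2 stands lowest of the two numbers, and the gap lies beyond the scatter. The next entry is compound 3 (`COC(=O)c1sc2cccc(C)c2c1Nc1cc(OC)c(OC)c(OC)c1`), which is compound 2 with methyl in place of hydrogen on an aromatic carbon, ortho to a fused ring and meta to a fused ring. Within the data shown here, no two measured compounds differ in one place only, so this change has no direct precedent. A rise beyond the scatter in this assay is expected, towards weaker inhibition, though smaller than the gap between the two measured compounds. The expected size is a 3.4-fold higher number from compound 2 to compound 3 (0.53 log units; beyond the scatter) as an estimate. For compound 3 the estimated value is 600 nM with an expected range of 150 nM to 2200 nM in this read-out.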

Compound 3, half-maximal inhibitory concentration: 2510 nM
Estimate against measurement, compound 3: 4.2-fold (0.62 log units) below; the whole stated range lies below it.
By their numbers in this assay, from the lowest: compound 2; then compounds 1 and 3 (each within the scatter of the next).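

In this assay methyl in place of hydrogen on this aromatic carbon, ortho to a fused ring and meta to a fused ring, brings a 14-fold higher number from compound 2 to compound 3 (1.15 log units; beyond the scatter) as a large step towards weaker inhibition. With that methyl present, hydrogen in place of methyl on the saturated chain carbon bound to an oxygen next to a carbonyl group gives a 1.3-fold higher number from compound 1 to compound 3 (0.11 log units; within the scatter) and leaves the two compounds indistinguishable in this assay. Nothing available bears on the reason for the large step.

On these data alone, whether a chlorine, an amine or a longer chain on this aromatic carbon would behave as methyl does remains open. Also open, as far as these compounds go, is whether methyl on the other carbons of that ring would carry the same penalty.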